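Amide chain lengthening from compound 3 to compound 4

This account rests on a few compounds, and the source may have more. Where it says the series, first, only, none or still open, it means among the compounds named here.

Measured so far:
compound 1 `CNC(=O)CC1CCc2cc(OC)c(OC)cc21` gives 33.3% in a functional assay on the whole organism (strain Wistar) for inhibition, with Rattus norvegicus as the target, read by paw edema, with stated times of 60 min and 24 h, at a dose of 100 mg/kg by the oral route; on this read-out higher numbers stand for more inhibition at the one dose given (going by the name of the read-out) and lower numbers for less inhibition
compound 2 `CCN(CC)C(=O)CC1CCc2cc(OC)c(OC)cc21` gives 16.7%
compound 3 `CCCNC(=O)CC1CCc2cc(OC)c(OC)cc21` gives 26.7%

Compound 3 sits between the other two numbers, yet both gaps are within the scatter: a number 6.6 percentage points lower from compound 1 to compound 3 (within the scatter) and a number 10 percentage points higher from compound 2 to compound 3 (within the scatter). Among the measured compounds shown here, only the step of a number 16.6 percentage points lower from compound 1 to compound 2 (beyond the scatter) is beyond the scatter, and it concerns two alkyl groups on the amide nitrogen rather than a longer single chain.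

Compound 4 `CCCCNC(=O)CC1CCc2cc(OC)c(OC)cc21` differs from compound 3 by methyl in place of hydrogen on a saturated chain carbon, three bonds along the chain from an amide-type nitrogen. For the measured compounds named here, the closest precedent is the chain growth a number 6.6 percentage points lower from compound 1 to compound 3 (within the scatter), which stayed within the scatter. One further methyl is therefore expected to give no step beyond the scatter, at most a slight drift downward.

Compound 4 is expected to give 24%, between 10% and 38%. That estimate means an expected step of a number 2.7 percentage points lower from compound 3 to compound 4 (within the scatter), within the scatter.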

Compound 4, a percentage reported as inhibition, in the whole organism at one dose (the size of the read-out at that dose, not a potency): 36.7%
Estimate against measurement, compound 4: 12.7 percentage points below; the measured number falls inside the stated range.
By their numbers in this assay, from the lowest: compounds 2, 3, 1 and 4 (each within the scatter of the next, the first and the last beyond it).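

In this assay methylamino, propylamino and butylamino on the carbonyl carbon stay within the scatter of one another, with a number 10 percentage points higher from compound 3 to compound 4 (within the scatter) and a number 3.4 percentage points higher from compound 1 to compound 4 (within the scatter) as the new steps. Butylamino in place of diethylamino gives a second step beyond the scatter, a number 20 percentage points higher from compound 2 to compound 4 (beyond the scatter), although compound 3 remains within the scatter of compound 2. Nothing available here bears on why these numbers fall as they do. Still open, going by these compounds, is how a longer chain such as hexylamino would read at this position. On these data alone, a cyclic amine on the carbonyl carbon also remains open.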